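The source may report more compounds than this note shows. Statements on the series, on what has been measured and on what is new or still open speak of the compounds shown alone.

Working notes on the series. Of the compounds shown here, two have numbers so far in a functional assay on MCF7 cells (Homo sapiens) for antiproliferative activity, read by MTT assay, with a stated time of 24 h; on this read-out higher numbers stand for weaker inhibition and lower numbers for stronger inhibition. Compound 1 `Cc1ccc(-c2nn(-c3ccccc3)cc2-c2nc3ccccc3n2S(=O)(=O)c2ccc(C)cc2)cc1` gives 570 nM, and compound 2 `O=[N+]([O-])c1ccc(S(=O)(=O)n2c(-c3cn(-c4ccccc4)nc3-c3ccc(F)cc3)nc3ccccc32)cc1` gives 1370 nM. Compound 2 therefore holds the higher of the two numbers, and its gap to compound 1 lies beyond the scatter.

The next compound to be read in this assay is compound 3 `O=S(=O)(c1ccc(Br)cc1)n1c(-c2cn(-c3ccccc3)nc2-c2ccc(F)cc2)nc2ccccc21`, which departs from compound 2 at a single place: bromo in place of nitro on an aromatic carbon. In short, the 4-nitrophenyl becomes 4-bromophenyl.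

Within the data shown here, no measured pair differs in one place only, so the effect of this change has no direct precedent. Among the measured compounds shown here, the only guide is the span of the two numbers, with compound 1 at 570 nM as the lower reference. A modest move toward a lower number is expected, and it may not clear the scatter. The estimated size is a 1.4-fold lower number from compound 2 to compound 3 (0.16 log units; within the scatter). For compound 3 the estimated value is 950 nM, with an expected range of 350 nM to 2600 nM.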

Compound 3, half-maximal inhibitory concentration: 2630 nM
Compound 3: middle estimate off by 2.8-fold (0.44 log units), on the low side; the whole stated range lies below it.
By their numbers in this assay, from the lowest: compound 1; then compounds 2 and 3 (each within the scatter of the next).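

Among these compounds, this is the first step that can be read at a single place: in this assay, bromo in place of nitro on an aromatic carbon, para to a large group, gives a 1.9-fold higher number from compound 2 to compound 3 (0.28 log units; within the scatter). The two compounds therefore cannot be ranked, even though the exchange replaces a group of 3 heavy atoms and 2 hydrogen-bond acceptors with a single bromine atom that has no hydrogen-bond acceptors, so this one pair shows no sensitivity to the change beyond the scatter. Nothing on hand explains this reading.

Still open, from the compounds shown here alone, is how an amine, a carboxylic acid, a methoxy group or a plain hydrogen at this place would read against the nitro and bromo compounds, and so whether the place responds to any exchange at all. Also open, going by these compounds, is whether the same exchange of nitro for bromo would read alike on a sulfonyl-bearing compound that differs elsewhere, as compound 1 does, because a single pair on a single background cannot show this.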